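Swapping the Pyrrolidine Substituent on a Shared Core

The compounds below may be only part of what the source reports. "The series", "measured", "known", "first", "only" and "open" are said of these compounds alone.

Measured compounds:
Compound 1 `Nc1ncnc2nc(-c3ccc(N4CCC5(CC4)COCO5)nc3)cc(-c3cccc(Br)c3)c12` gives 2 umol/kg in a functional assay on the whole organism with Rattus norvegicus as the target; on this read-out lower numbers stand for an effect already at smaller amounts and higher numbers for an effect only at larger amounts of compound.
Compound 2 `COCCOC1CCN(c2ccc(-c3cc(-c4cccc(Br)c4)c4c(N)ncnc4n3)nn2)CC1` gives 3 umol/kg in this assay.
Compound 3 `Nc1ncnc2nc(-c3ccc(N4CCC[C@H]4CO)nn3)cc(-c3cccc(Br)c3)c12` gives 10 umol/kg in this assay.

Among these three, compound 3 has the highest number, meaning the largest dose is needed for its effect. Its nearest neighbour is compound 2, whose value is lower, and compound 1 sits lower still; both gaps lie beyond the usual scatter of this assay.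

The unmeasured compound 4 `CCO[C@H]1CN(c2ccc(-c3cc(-c4cccc(Br)c4)c4c(N)ncnc4n3)nn2)C[C@H]1OCC` is reached from compound 3 by one change: 3,4-diethoxypyrrolidin-1-yl in place of 2-(hydroxymethyl)pyrrolidin-1-yl on an aromatic carbon. Among the measured compounds shown here, the only measured step that bears on this change is a 3.3-fold higher number from compound 2 to compound 3 (0.52 log units; beyond the scatter), where a ring substituent carrying a hydroxymethyl group arrived in place of a ring substituent carrying only ether oxygens and the number rose. The change to compound 4 runs the other way, trading the hydroxymethyl-bearing ring for one carrying two ethoxy groups, so compound 4 is expected to move back toward the lower numbers of compound 2 and compound 1, as a 2.5-fold lower number from compound 3 to compound 4 (0.40 log units; beyond the scatter). The estimate for compound 4 is therefore 4 umol/kg, with a plausible range from 1.5 umol/kg to 12 umol/kg.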

Compound 4, dose for half-maximal effect: 3 umol/kg
The estimate for compound 4 lay 1.3-fold (0.12 log units) above the measured number; the measured number falls inside the stated range.
By their numbers in this assay, from the lowest: compounds 1, 2 and 4 (each within the scatter of the next); then compound 3.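

On the aromatic carbon that carries this group, the five-membered ring stays while its substituents change: 3,4-diethoxypyrrolidin-1-yl in place of 2-(hydroxymethyl)pyrrolidin-1-yl gives a 3.3-fold lower number from compound 3 to compound 4 (0.52 log units; beyond the scatter) in this assay and so reverses the rise seen earlier (a 3.3-fold higher number from compound 2 to compound 3 (0.52 log units; beyond the scatter)). That earlier step changed ring size and substituents together, whereas this one shows that a five-membered ring at this position does not by itself go with the higher number, and the comparison with the six-membered ring of 4-(2-methoxyethoxy)piperidin-1-yl gives no change at the digits printed from compound 2 to compound 4 (within the scatter) in the same assay. No measurement here accounts for either result, so the numbers describe what happened without explaining it.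

The step from compound 3 to compound 4 removes the hydroxymethyl group, adds two ethoxy groups and alters the defined stereocentres all at once, so the contribution of each change remains unresolved. Also open, going by these compounds, is how the number would respond to a methoxymethyl group on the same pyrrolidine, or to an amine or a carboxylic acid on that ring.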